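This account rests on a few compounds, and the source may have more. Where it says the series, first, only, none or still open, it means among the compounds named here.

In a functional assay on HEK293 cells (Homo sapiens) for cytotoxicity (on this read-out lower numbers stand for higher toxicity in this test and higher numbers for lower toxicity in this test), compound 3 `COc1ccc([C@H]2CC(=O)N(c3ccccc3C#N)C2)cc1OC1CCCC1` gives > 10000 nM, which is a limit of the assay and not a number. Compound 1 `COc1ccc([C@H]2CC(=O)N(Cc3cccc([N+](=O)[O-])c3)C2)cc1OC1CCCC1` gives > 10000 nM, also a limit. Compound 2 `COc1ccc([C@H]2CC(=O)N(c3cccc(N)c3C)C2)cc1OC1CCCC1` gives > 10000 nM, again a limit. The picture so far is therefore (the limit of > 10000 nM in this assay, at which 3 of the 3 values shown sit), and compound 3 has no number that sets it apart from the other two.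

The next compound, compound 4 `COc1ccc([C@H]2CC(=O)N(c3cccc(C#N)c3)C2)cc1OC1CCCC1`, has the same atoms as compound 3, joined differently: 3-cyanophenyl in place of 2-cyanophenyl on an amide-type nitrogen in a ring. In words, 3-cyanophenyl stands in place of 2-cyanophenyl on an amide-type nitrogen in a ring.

The measured steps that bear on this change are a step that the two limits leave unreadable from compound 1 to compound 3, a step that the two limits leave unreadable from compound 2 to compound 3 and a step that the two limits leave unreadable from compound 1 to compound 2. All three swap the group on that same nitrogen, yet none has a size to carry over, so no step beyond the scatter is expected, in either direction.

The expected change is a number no higher from compound 3 to compound 4 (the limit leaves the size open). For compound 4 the estimate is 10000 nM, with an expected range from 4000 nM to 20000 nM, and the assay may well report only a limit again.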

Compound 4, half-maximal cytotoxic concentration: > 10000 nM
Compound 4 ended at the assay's limit; the forecaster's own chance of this, stated with the estimate: 85%; the middle value sits exactly at the limit.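

In this assay compound 4 gives > 10000 nM, which is a limit of the assay. Its steps from compound 1, compound 2 and compound 3 therefore cannot be read: the limit of > 10000 nM in this assay, at which 4 of the 4 values shown sit.

The compounds shown leave open whether the group on the amide-type nitrogen changes anything in this assay.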